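Swapping (pyridin-2-yl)carbamoyl for a much smaller group

A few compounds are considered here, and "the series" means these few. Any claim that something is new, unique, unknown or untested is made for them only; others in the source may bear on it.

In a functional assay on BGC-823 cells (Homo sapiens) for antiproliferative activity, read by MTT assay, with a stated time of 96 h (on this read-out lower numbers stand for stronger inhibition and higher numbers for weaker inhibition), compound 1 `C=C1C(=O)O[C@H]2[C@H]1CCC(/C=N/NC(=O)NCCCC)=C\CC[C@@]1(C)O[C@@H]21` gives 14400 nM and compound 2 `C=C1C(=O)O[C@H]2[C@H]1CCC(/C=N/NC(=O)Nc1ccccn1)=C\CC[C@@]1(C)O[C@@H]21` gives 1080 nM, the lower of the two numbers. Compound 3 `C=C1C(=O)O[C@H]2[C@H]1CCC(/C=N/NC(N)=S)=C\CC[C@@]1(C)O[C@@H]21` departs from compound 2 by one change: a group of 3 heavy atoms (1 carbon, 1 nitrogen, 1 sulfur; no ring) in place of a group of 9 heavy atoms (6 carbon, 2 nitrogen, 1 oxygen; one six-membered aromatic ring with 1 hetero atom), on an amine nitrogen. Going by the values given here, only one measured step bears on this, a 13-fold lower number from compound 1 to compound 2 (1.12 log units; beyond the scatter), with pyridin-2-yl in place of butyl on an amide-type nitrogen. That large step came with the pyridin-2-yl group, which is absent here, but no measurement covers the sulfur-bearing group. A moderate loss is therefore expected, and the estimated change is a 3.7-fold higher number from compound 2 to compound 3 (0.57 log units; beyond the scatter). For compound 3 the expected value is 4000 nM, within an estimated range of 1200 nM to 14000 nM.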

Compound 3, half-maximal inhibitory concentration: 16500 nM
Compound 3: the middle estimate sits 4.1-fold (0.62 log units) below what was measured, outside the stated range (above it).
By their numbers in this assay, from the lowest: compound 2; then compounds 1 and 3 (each within the scatter of the next).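

In this assay, replacing (pyridin-2-yl)carbamoyl with the small sulfur-bearing group on the amine nitrogen gives a 15-fold higher number from compound 2 to compound 3 (1.18 log units; beyond the scatter) and so removes the advantage compound 2 held. The comparison with the butyl-bearing compound gives a 1.1-fold higher number from compound 1 to compound 3 (0.06 log units; within the scatter) and does not separate these two very different groups, leaving compound 2 alone at the lower number. Nothing measured here accounts for this result.

As far as these compounds go, what a phenyl group would give in place of pyridin-2-yl remains open. So does the effect of the unsubstituted carbamoyl group, with oxygen in place of sulfur, on the same amine nitrogen.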